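The source may hold more compounds than are shown below. What is called first, only, known or untested is meant among the compounds shown, and "the series" means these compounds.

Measured compounds:
compound 1 `O=C(N/N=C/c1ccc(Br)cc1)N1CCc2ncnc(Nc3ccc(F)c(Cl)c3)c2C1`, 12100 nM
compound 2 `O=C(N/N=C/c1ccc(F)cc1)N1CCc2ncnc(Nc3ccc(F)c(Cl)c3)c2C1`, 10900 nM
compound 3 `O=C(N/N=C/c1ccc(Br)cc1)N1CCc2ncnc(Nc3cccc(C(F)(F)F)c3)c2C1`, 11400 nM

All three were read in a functional assay on MKN-45 cells (Homo sapiens) for cytotoxicity, read by MTT assay, with a stated time of 72 h; a lower number here means a stronger inhibitor, a higher number a weaker inhibitor. The step of a 1.1-fold lower number from compound 1 to compound 2 (0.05 log units; within the scatter) comes from the change (fluoro in place of bromo on an aromatic carbon). The cores of compound 1 and compound 3 differ by 3-(trifluoromethyl)phenyl in place of 3-chloro-4-fluorophenyl on a nitrogen on an aromatic ring, with the step of a 1.1-fold lower number from compound 1 to compound 3 (0.03 log units; within the scatter). Compound 4 `O=C(N/N=C/c1ccc(F)cc1)N1CCc2ncnc(Nc3cccc(C(F)(F)F)c3)c2C1` is not yet measured; it differs from compound 3 by fluoro in place of bromo on an aromatic carbon, the same change as that from compound 1 to compound 2, in the same place. The step from compound 3 to compound 4 is expected to be a 1.1-fold lower number from compound 3 to compound 4 (0.04 log units; within the scatter), resting on the near-flat step a 1.1-fold lower number from compound 1 to compound 2 (0.05 log units; within the scatter) and on the value of compound 3, 11400 nM. Compound 4 is therefore estimated at 10500 nM in this assay, within 5500 nM to 20000 nM.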

Compound 4, half-maximal inhibitory concentration: 4000 nM
Compound 4: middle estimate off by 2.6-fold (0.42 log units), on the high side, and the stated range ends above it.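

In this assay, fluoro in place of bromo gives a 2.9-fold lower number from compound 3 to compound 4 (0.45 log units; beyond the scatter), and 3-(trifluoromethyl)phenyl in place of 3-chloro-4-fluorophenyl gives a 2.7-fold lower number from compound 2 to compound 4 (0.44 log units; beyond the scatter). The fluoro change is neither shown to depend on the core nor shown to carry over unchanged, as its two readings do not separate: the same change on two cores in this assay, a 1.1-fold lower number (0.05 log units; within the scatter) from compound 1 to compound 2 and a 2.9-fold lower number (0.45 log units; beyond the scatter) from compound 3 to compound 4, 2.6-fold (0.41 log units) apart, within the scatter of two such steps The 3-(trifluoromethyl)phenyl change reads the same way, so these four compounds establish no interaction between the two places: the same change on two cores in this assay, a 1.1-fold lower number (0.03 log units; within the scatter) from compound 1 to compound 3 and a 2.7-fold lower number (0.44 log units; beyond the scatter) from compound 2 to compound 4, 2.6-fold (0.41 log units) apart, within the scatter of two such steps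

Open, on these data alone, is whether the lower number of compound 4 persists with other groups in place of fluoro, such as a nitrile or a methoxy group. Also open, as far as these compounds go, is how an amine or a carboxylic acid would read in that place.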